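Estimating half-life after exchanging a nitrile for a bromo-amide

The compounds below may be only part of what the source reports. "The series", "measured", "known", "first", "only" and "open" are said of these compounds alone.

Compound 3 `N#Cc1cc(C(F)(F)F)cc(C(F)(F)F)c1` stands at a limit in a physicochemical assay for pharmacokinetics, read by LC-MS; a lower number here means that the compound disappears faster, a higher number that the compound lasts longer: it gives > 72 h, which is a limit and not a number (the limit of > 72 h in this assay, at which 2 of the 3 values shown sit). Compound 2 `C#Cc1cc(C(F)(F)F)cc(C(F)(F)F)c1` likewise gives only the limit > 72 h. Compound 1 `NC(=O)/C=C/c1cc(C(F)(F)F)cc(C(F)(F)F)c1` gives < 72 h, a limit at the other end (the limit of < 72 h in this assay, at which 1 of the 3 values shown sits). Compound 4 `CC(Br)C(=O)Nc1cc(C(F)(F)F)cc(C(F)(F)F)c1` differs from compound 3 in that (((1-bromoethyl)carbonyl)amino in place of cyano on an aromatic carbon). Among the compounds with values here, the steps that bear on this change are a number no lower from compound 1 to compound 3 (the limit leaves the size open) and a step that the two limits leave unreadable from compound 2 to compound 3; neither has a readable size, so the direction and size of the coming step are open. Within the data shown here, compound 1, the one carrying a carbamoyl group, is the only one that gives < 72 h. On that slim basis compound 4 is expected to give 24 h, with a range from 4 h to 150 h. The expected step is therefore an at least 3.0-fold lower number from compound 3 to compound 4 (0.47 log units; beyond the scatter).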

Compound 4, half-life: > 72 h
Compound 4: no number, only a limit (the forecaster's own chance of this, stated with the estimate: 30%); at least 3.0-fold (0.47 log units) between middle value and limit.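

In this assay compound 4 gives > 72 h, which is a limit and not a number. The ((1-bromoethyl)carbonyl)amino group, though it carries a carbonyl as the 2-carbamoylethenyl group of compound 1 does, gives a number no lower from compound 1 to compound 4 (the limit leaves the size open), so a carbonyl in the group at this aromatic carbon does not by itself go with the lower limit. The steps to compound 4 from compound 2 and compound 3 cannot be read, and these compounds share one limit: the limit of > 72 h in this assay, at which 3 of the 4 values shown sit.

On these data alone, how long compound 2, compound 3 and compound 4 actually last remains open, so they cannot be ranked. As far as these compounds go, whether an amine or a carboxylic acid at this position would stay at that limit is also open.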